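Pyrazolyl for Hydroxymethyl at the Chain End

A few compounds are considered here, and "the series" means these few. Any claim that something is new, unique, unknown or untested is made for them only; others in the source may bear on it.

Compound 1 `CCCCNc1nc(N)nc(C)c1CCCN1C(=O)c2ccccc2C1=O`: 453 nM
Compound 2 `C#Cc1c(C)nc(N)nc1NCCCC`: 4900 nM
Compound 3 `CCCCNc1nc(N)nc(C)c1CCCCO`: 1310 nM

In an assay on HEK293 cells for agonist activity at Toll-like receptor 8 (Homo sapiens), read by spectrophotometry (a lower number here means that less compound is needed, a higher number that more compound is needed for the effect), compound 3 gives 1310 nM, the second highest of the three numbers; compound 1 gives the nearest number and compound 2 the furthest. Compound 4 `CCCCNc1nc(N)nc(C)c1CCCn1cccn1` differs from compound 3 by 1H-pyrazol-1-yl in place of hydroxymethyl on a saturated chain carbon, three bonds along the chain from an aromatic carbon. Among the measured compounds shown here, no measured step covers this exact change. For the measured compounds named here, the one step available, a 3.7-fold lower number from compound 2 to compound 3 (0.57 log units; beyond the scatter), shows that lengthening the substituent on the aromatic carbon helps, and the values of compound 1 and compound 3 together suggest that an aromatic ring at the chain end is tolerated or favoured. Compound 4 is therefore expected to show a modest lowering, a 2.2-fold lower number from compound 3 to compound 4 (0.34 log units; beyond the scatter), with an estimated value of 600 nM and a range from 200 nM to 1800 nM.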

Compound 4, half-maximal effective concentration: 1050 nM
Compound 4: the middle estimate sits 1.8-fold (0.24 log units) below what was measured; low and high end bracket the measured number.
By their numbers in this assay, from the lowest: compound 1; then compounds 4 and 3 (each within the scatter of the next); then compound 2.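

In this assay, 1H-pyrazol-1-yl in place of hydroxymethyl gives a 1.2-fold lower number from compound 3 to compound 4 (0.10 log units; within the scatter), so compound 3 and compound 4 cannot be told apart. On this saturated chain carbon, three bonds along the chain from an aromatic carbon, the chain end thus accepts a five-membered aromatic ring in place of the hydroxyl-bearing group, and the hydrogen-bond donor of hydroxymethyl is not needed to keep this level. Still open, from the compounds shown here alone, is whether an amine, a carboxylic acid or a longer chain at this place would move the number beyond the scatter. No available measurement accounts for this result.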